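Aryl swap on the carbonyl carbon of the shared core

The source may report more compounds than this note shows. Statements on the series, on what has been measured and on what is new or still open speak of the compounds shown alone.

Compound 1 `COc1cc(-c2cc(/C=C/C(=O)c3ccc(N)cc3)[nH]n2)cc(OC)c1OC` is measured in a functional assay on SNB-19 cells (Homo sapiens) for cytotoxicity, read by sulforhodamine B assay, with a stated time of 48 h, tested at 0.1 uM (a higher number here means a weaker effect of the compound at the concentration tested, a lower number a stronger effect), where compound 1 gives 94%. This is the highest of three numbers; compound 2 `COc1ccc(-c2cc(/C=C/C(=O)c3ccc(OC)c(OC)c3)[nH]n2)cc1` gives 90% in this assay and compound 3 `COc1ccc(-c2cc(/C=C/C(=O)c3ccc(N)cc3)[nH]n2)cc1OC` gives 90%, both within the scatter of compound 1, so no ordering among the three is supported. Going by the values given here, the single one-place step in the set, a number 4 percentage points lower from compound 1 to compound 3 (within the scatter), removes a methoxy from the aryl on the shared core and leaves the read-out unchanged beyond the scatter.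

Compound 4 `COc1ccc(C(=O)/C=C/c2cc(-c3cc(OC)c(OC)c(OC)c3)n[nH]2)cc1OC` is not yet measured. It differs from compound 1 by 3,4-dimethoxyphenyl in place of 4-aminophenyl on a carbonyl carbon. Among the compounds with values here, no measured step tests exactly this exchange; compound 2 carries the 3,4-dimethoxyphenyl on the carbonyl carbon and compound 3 the 4-aminophenyl, but they also differ in the other aryl, and their values show no gap. Within the data shown here, with every number so far lying close together, no step beyond the scatter is expected in this assay. The estimate for compound 4 is 91%, in the range 80% to 100%, which corresponds to an expected step of a number 3 percentage points lower from compound 1 to compound 4 (within the scatter).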

Compound 4, a percentage reported as activity, at one concentration (the size of the read-out at that concentration, not a potency): 93%
Beside the measured number, compound 4's estimate is 2 percentage points below it; the range from low to high includes it.
By their numbers in this assay, from the lowest: compounds 2, 3, 4 and 1 (each within the scatter of the next).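

On the carbonyl carbon, the first direct test of 3,4-dimethoxyphenyl in place of 4-aminophenyl, with the rest of the structure held constant, gives a number 1 percentage points lower from compound 1 to compound 4 (within the scatter) in this assay. The earlier pair of compound 2 and compound 3 could not isolate this exchange, as the two also differ in the other aryl; the new step shows that this position tolerates the swap without a change beyond the scatter at the concentration tested. Nothing available bears on why the read-out stays flat across this exchange.

On these data alone, whether a carboxylic acid, a hydroxyl or an unsubstituted phenyl on the carbonyl carbon would move the number remains open. A single concentration also leaves open whether these compounds would separate at higher concentrations, where one could show a stronger or weaker effect than another at the concentration in question.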